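The compounds below may be only part of what the source reports. "The series", "measured", "known", "first", "only" and "open" are said of these compounds alone.

Compound 2 `CC(C)Oc1cccc(-c2csc(NC(=O)c3ccc([N+](=O)[O-])o3)n2)c1` holds the higher of the two numbers measured in an ADME assay on Vero cells (Chlorocebus sabaeus) for cytotoxicity, read by MTT assay, with a stated time of 72 h (a lower number here means a stronger inhibitor, a higher number a weaker inhibitor), giving 69500 nM; compound 1 `COc1cccc(-c2csc(NC(=O)c3ccc([N+](=O)[O-])o3)n2)c1` gives 58700 nM, and the step of a 1.2-fold higher number from compound 1 to compound 2 (0.07 log units; within the scatter) is within the scatter. Compound 3 `O=C(Nc1nc(-c2cccc(NC(=O)C3CC3)c2)cs1)c1ccc([N+](=O)[O-])o1` differs from compound 2 by (cyclopropylcarbonyl)amino in place of isopropoxy on an aromatic carbon. For the measured compounds named here, the only measured step, a 1.2-fold higher number from compound 1 to compound 2 (0.07 log units; within the scatter), also changes the group on that aromatic carbon, and since it produced no movement beyond the scatter, no clear direction can be read from it for a change of this kind. Compound 3 is therefore expected to show a step of about a 1.2-fold lower number from compound 2 to compound 3 (0.06 log units; within the scatter), with an estimate of 60000 nM and a range from 25000 nM to 140000 nM.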

Compound 3, half-maximal inhibitory concentration: 35700 nM
Compound 3: middle estimate off by 1.7-fold (0.23 log units), on the high side, and the stated range covers the measured number.
By their numbers in this assay, from the lowest: compounds 3, 1 and 2 (each within the scatter of the next).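

Putting (cyclopropylcarbonyl)amino on this aromatic carbon in place of isopropoxy or methoxy adds a three-membered ring and a hydrogen-bond donor, yet in this assay both steps remain within the scatter: a 1.9-fold lower number from compound 2 to compound 3 (0.29 log units; within the scatter) and a 1.6-fold lower number from compound 1 to compound 3 (0.22 log units; within the scatter). The position therefore tolerates an amide-linked group as well as the two alkoxy groups without a clear shift in this read-out. No measured evidence bears on this result. As far as these compounds go, whether an amine or a carboxylic acid on this carbon would move the number beyond the scatter remains open.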